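Swapping a Benzoyl Cap for a Dienoyl One

The source may hold more compounds than are shown below. What is called first, only, known or untested is meant among the compounds shown, and "the series" means these compounds.

For the measured compounds named here, compound 2 `CCCCCCCCCCCCCCCCCCNC(=O)[C@@H](NC(=O)c1ccccc1)[C@@H](C)O` gives 113000 nM in a functional assay on A-431 cells (Homo sapiens) for cytotoxicity, read by MTT assay, with a stated time of 48 h (on this read-out higher numbers stand for weaker inhibition and lower numbers for stronger inhibition), the highest of the two numbers measured so far; compound 1 `CCCCCCCCCCCCNC(=O)[C@@H](NC(=O)c1ccccc1)[C@@H](C)O` gives 41200 nM, and the single measured step, a 2.7-fold higher number from compound 1 to compound 2 (0.44 log units; beyond the scatter), concerns only the length of the chain. Compound 3 `C/C=C/C=C/C(=O)N[C@H](C(=O)NCCCCCCCCCCCCCCCCCC)[C@@H](C)O` differs from compound 2 in a different place: penta-1,3-dien-1-yl in place of phenyl on a carbonyl carbon. Going by the values given here, no measured step touches this exchange, so the data give no size and no direction for it. With nothing to go on, the estimate for compound 3 stays close to the number just seen: 100000 nM, within a range from 30000 nM to 300000 nM, which is expected to mean a 1.1-fold lower number from compound 2 to compound 3 (0.05 log units; within the scatter).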

Compound 3, half-maximal inhibitory concentration: 187000 nM
Beside the measured number, compound 3's estimate is 1.9-fold (0.27 log units) below it; the measured number falls inside the stated range.
By their numbers in this assay, from the lowest: compound 1; then compounds 2 and 3 (each within the scatter of the next).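

In this assay, putting penta-1,3-dien-1-yl in place of phenyl on the carbonyl carbon gives a 1.7-fold higher number from compound 2 to compound 3 (0.22 log units; within the scatter), so this exchange produces no change that can be told from ordinary repeat variation. In this one pair, the aromatic ring can give way to an open chain with two double bonds without a readable shift. No supporting measurement bears on this result. Still open, going by these compounds, is whether the same exchange would read alike on the shorter chain of compound 1, and what an amine or a carboxylic acid on the cap would do.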